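This account rests on a few compounds, and the source may have more. Where it says the series, first, only, none or still open, it means among the compounds named here.

Measured in a functional assay on HT-29 cells (Homo sapiens) for antiproliferative activity, with a stated time of 48 h; a higher number here means a weaker inhibitor, a lower number a stronger inhibitor:
- Compound 1 `CCNC(=O)NCc1ccc(C(C)(C)C)cc1`: > 100000 nM (a limit)
- Compound 2 `CC(C)(C)c1ccc(CNC(=O)CCCl)cc1`: 87000 nM

Within the data shown here, compound 2, at 87000 nM, holds the only true number in this small set. The entry for compound 1 is a limit of the assay, not a number.

The next compound is compound 3 `C=CC(=O)NCc1ccc(C(C)(C)C)cc1`, and the change is vinyl in place of 2-chloroethyl on a carbonyl carbon. In words, vinyl takes the place of 2-chloroethyl on a carbonyl carbon.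

Among the measured compounds shown here, the one measured step at this same carbonyl carbon is an at least 1.1-fold lower number from compound 1 to compound 2 (0.06 log units; that floor lies within the scatter). It is a different exchange, so it offers only a weak guide. With so little to go on, no step beyond the scatter is expected in this assay. The expected step is a 1.2-fold lower number from compound 2 to compound 3 (0.09 log units; within the scatter). For compound 3 the estimated value is 70000 nM, with an expected range of 25000 nM to 100000 nM.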

Compound 3, half-maximal inhibitory concentration: > 100000 nM
Compound 3: only a limit was reported (the forecaster's own chance of this, stated with the estimate: 25%); middle value at least 1.4-fold (0.15 log units) away from the limit.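

In this assay, compound 3 gives > 100000 nM, which is a limit of the assay and not a number. Vinyl in place of 2-chloroethyl on this carbonyl carbon gives an at least 1.1-fold higher number from compound 2 to compound 3 (0.06 log units; that floor lies within the scatter), so this exchange brings no gain, although the true size of the step stays unknown and may exceed that floor. The step from compound 1 to compound 3 cannot be read, and the set now offers only one true number: the limit of > 100000 nM in this assay, at which 2 of the 3 values shown sit.

Still open, on these data alone, is whether any group on this carbonyl carbon can bring the number clearly down, for example a longer chain such as 3-chloropropyl or a chain ending in an amine. Also open, as far as these compounds go, is whether compound 2's value reflects something particular to 2-chloroethyl, which a comparison with a plain propyl group could help to test.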